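The source may report more compounds than this note shows. Statements on the series, on what has been measured and on what is new or still open speak of the compounds shown alone.

In a functional assay on HCT-116 cells (Homo sapiens) for inhibition, read by CCK-8 assay, with a stated time of 48 h (a higher number here means a weaker inhibitor, a lower number a stronger inhibitor), compound 1 `COc1ccc(CN(C(=O)CSC(=S)N2CCN(C(=O)OC(C)(C)C)CC2)c2cc(OC)c(OC)c(OC)c2)cc1C` stands at > 20000 nM, which is a limit of the assay and not a number. For the measured compounds named here, compound 2 `COc1ccc(CN(C(=O)CSC(=S)N2CCN(C(=O)OC(C)(C)C)CC2)c2cc(OC)c(OC)c(OC)c2)cc1N` gives 352 nM, and compound 3 `COc1ccc(CN(C(=O)CSC(=S)N2CCN(C(=O)OC(C)(C)C)CC2)c2cc(OC)c(OC)c(OC)c2)cc1O` gives 128 nM, the lowest number so far. Amino in place of methyl on an aromatic carbon gave an at least 56-fold lower number from compound 1 to compound 2 (1.75 log units; beyond the scatter). Hydroxy in place of methyl gave an at least 150-fold lower number from compound 1 to compound 3 (2.19 log units; beyond the scatter), and hydroxy in place of amino gave a 2.8-fold lower number from compound 2 to compound 3 (0.44 log units; beyond the scatter). Compound 4 `COc1ccc(CN(C(=O)CSC(=S)N2CCN(C(C)=O)CC2)c2cc(OC)c(OC)c(OC)c2)cc1O` keeps the hydroxy group of compound 3 and carries a different change: methyl in place of tert-butoxy on a carbonyl carbon, or tert-butoxycarbonyl to acetyl. Going by the values given here, none of the measured steps touches that place, so they bear on it only indirectly and set no size for it. Since compound 3 already sits lowest at 128 nM, a modest move towards a higher number in this assay is expected, with wide uncertainty. The expected step is a 2.3-fold higher number from compound 3 to compound 4 (0.37 log units; beyond the scatter). For compound 4 the estimated value is 300 nM, with an expected range of 70 nM to 2500 nM.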

Compound 4, half-maximal inhibitory concentration: 780 nM
Beside the measured number, compound 4's estimate is 2.6-fold (0.41 log units) below it; measured number inside the range.
By their numbers in this assay, from the lowest: compound 3; then compound 2; then compound 4. At a limit, above all of these: compound 1.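

The earlier steps shown here all changed a group on an aromatic carbon, while this one shows that the place on a carbonyl carbon, whose other neighbours are amide-type nitrogen in a ring, also moves the number in this assay: methyl in place of tert-butoxy gave a 6.1-fold higher number from compound 3 to compound 4 (0.78 log units; beyond the scatter) with the hydroxy group kept. With the acetyl group, compound 4 still gives 780 nM, so inhibition in this assay does not depend entirely on the tert-butoxycarbonyl group. Nothing measured here bears on the cause of this step.

With only tert-butoxy and methyl shown on this carbonyl carbon, it remains open how an ethyl, a cyclopropyl or an amine would read there. Also open is whether the order of hydroxy and amino on the aromatic carbon holds with acetyl, since the amino group is shown only with tert-butoxycarbonyl.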